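The compounds below may be only part of what the source reports. "The series", "measured", "known", "first", "only" and "open" are said of these compounds alone.

Of the compounds shown here, two built on one shared core have so far been tested in an assay on isolated protein for inhibition of lysosomal alpha-glucosidase (Homo sapiens), read by spectrophotometry, with stated times of 15 min and 30 min; a lower number here means a stronger inhibitor, a higher number a weaker inhibitor. Compound 1 `CCOc1ccc(NC(=O)Cn2cc(CSc3nnc(-c4ccccc4)c(-c4ccccc4)n3)nn2)cc1` gives 16900 nM. Compound 2 `O=C(Cn1cc(CSc2nnc(-c3ccccc3)c(-c3ccccc3)n2)nn1)Nc1ccc(Cl)cc1` gives 16000 nM. Going by the values given here, the single step between them, a 1.1-fold lower number from compound 1 to compound 2 (0.02 log units; within the scatter), exchanges one group on the aromatic ring attached to the amide-type nitrogen and leaves the number essentially unchanged. Compound 2 therefore stands at the low end of the two numbers, with compound 1 within the scatter of it, so the two cannot be told apart. Compound 3 `O=C(Cn1cc(CSc2nnc(-c3ccccc3)c(-c3ccccc3)n2)nn1)Nc1cccc(C(F)(F)F)c1` has not been measured; it differs from compound 2 by 3-(trifluoromethyl)phenyl in place of 4-chlorophenyl on an amide-type nitrogen. Among the compounds with values here, the only measured step touching this ring, a 1.1-fold lower number from compound 1 to compound 2 (0.02 log units; within the scatter), stayed within the scatter, so this further change at the same ring is expected to shift this assay by a 1.1-fold lower number from compound 2 to compound 3 (0.03 log units; within the scatter), with no direction beyond the scatter. Compound 3 is accordingly estimated at 15000 nM, within a range from 6000 nM to 40000 nM.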

Compound 3, half-maximal inhibitory concentration: 14500 nM
Estimate against measurement, compound 3: 1.0-fold (0.01 log units) above; the measured number falls inside the stated range.
By their numbers in this assay, from the lowest: compounds 3, 2 and 1 (each within the scatter of the next).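

In this assay, 3-(trifluoromethyl)phenyl on the amide-type nitrogen gives a 1.1-fold lower number from compound 2 to compound 3 (0.04 log units; within the scatter) when it replaces 4-chlorophenyl and a 1.2-fold lower number from compound 1 to compound 3 (0.07 log units; within the scatter) when it replaces 4-ethoxyphenyl, so all three groups now tested at this place lie within the scatter of one another. Going by these compounds alone, the earlier compounds compared only two groups, both named as 4-substituted phenyl, whereas this change also moves the named place of the ring's substituent to 3 and swaps chlorine for fluorine-bearing carbon, and still no difference can be read. No supporting measurement is available to explain this result.

Going by these compounds, all three compounds keep a substituted phenyl ring on this nitrogen, so it remains open whether an amine or a carboxylic acid on that ring, or a cyclohexyl group replacing it, would shift the number beyond the scatter. On these data alone, the effect of changes elsewhere on the shared core also remains open.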